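Amide versus acid in the thiazole series: a paired change

The source may report more compounds than this note shows. Statements on the series, on what has been measured and on what is new or still open speak of the compounds shown alone.

Compound 1 `CN1CCN(c2ccc(Nc3nc(-c4cccc(NC(=O)c5ccc(Cl)cc5)c4)sc3C(=O)O)cc2)CC1` is the carboxylic acid of the series; in a functional assay on Ramos cells (Homo sapiens) for antiproliferative activity, read by CCK-8 assay, with a stated time of 72 h (on this read-out lower numbers stand for stronger inhibition and higher numbers for weaker inhibition), compound 1 gives 23300 nM. Compound 2 `CN1CCN(c2ccc(Nc3nc(-c4cccc(NC(=O)c5ccc(F)c(Cl)c5)c4)sc3C(=O)O)cc2)CC1` differs from it only in the benzoyl piece, (3-chloro-4-fluorophenyl in place of 4-chlorophenyl on a carbonyl carbon), and in this assay compound 2 gives 5600 nM, so the step is a 4.2-fold lower number from compound 1 to compound 2 (0.62 log units; beyond the scatter). Compound 3 `CN1CCN(c2ccc(Nc3nc(-c4cccc(NC(=O)c5ccc(Cl)cc5)c4)sc3C(N)=O)cc2)CC1` keeps the benzoyl piece of compound 1 but carries a different group on the core, (amino in place of hydroxy on a carbonyl carbon); in this assay compound 3 gives 1360 nM, a step of a 17-fold lower number from compound 1 to compound 3 (1.23 log units; beyond the scatter). Compound 3 holds the lowest of the three numbers.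

Compound 4 `CN1CCN(c2ccc(Nc3nc(-c4cccc(NC(=O)c5ccc(F)c(Cl)c5)c4)sc3C(N)=O)cc2)CC1` is not yet measured. It stands to compound 3 as compound 2 stands to compound 1: the change is 3-chloro-4-fluorophenyl in place of 4-chlorophenyl on a carbonyl carbon, and the place is described in the same words for both pairs, so this is the same change made on the carbamoyl core instead of the carboxy core. If the change carries over, the step from compound 3 to compound 4 is expected to be about a 3.4-fold lower number from compound 3 to compound 4 (0.53 log units; beyond the scatter), resting on the measured step from compound 1 to compound 2 of a 4.2-fold lower number from compound 1 to compound 2 (0.62 log units; beyond the scatter). Compound 4 is therefore estimated at 400 nM, with a likely range of 150 nM to 1000 nM.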

Compound 4, half-maximal inhibitory concentration: 4830 nM
Compound 4: the middle estimate sits 12-fold (1.08 log units) below what was measured; measured number outside the range, above it.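

In this assay the benzoyl change does not carry over from the carboxy core to the carbamoyl core; on the carbamoyl core it runs the other way, giving a 3.6-fold higher number from compound 3 to compound 4 (0.55 log units; beyond the scatter), and the two steps differ: the same change on two cores in this assay, a 4.2-fold lower number (0.62 log units; beyond the scatter) from compound 1 to compound 2 and a 3.6-fold higher number (0.55 log units; beyond the scatter) from compound 3 to compound 4, 15-fold (1.17 log units) apart, beyond the scatter of two such steps. The change of hydroxy to amino on the carbonyl carbon also depends on the benzoyl piece: with 3-chloro-4-fluorophenyl it gives a 1.2-fold lower number from compound 2 to compound 4 (0.06 log units; within the scatter), so the drop seen with 4-chlorophenyl does not reappear: the same change on two cores in this assay, a 17-fold lower number (1.23 log units; beyond the scatter) from compound 1 to compound 3 and a 1.2-fold lower number (0.06 log units; within the scatter) from compound 2 to compound 4, 15-fold (1.17 log units) apart, beyond the scatter of two such steps. These four compounds show that the two changes do not add up in this one assay, but they do not show why, nor how either change behaves with any other group.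

Open, as far as these compounds go, is whether a plain 4-fluorophenyl or 3-chlorophenyl in the benzoyl piece would follow compound 2 or compound 4 on each core. Also open, from the compounds shown here alone, is whether a methyl ester or a nitrile in place of the carboxy or carbamoyl group would keep the same dependence on the benzoyl piece.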